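The compounds below may be only part of what the source reports. "The series", "measured", "known", "first", "only" and "open" are said of these compounds alone.

Working notes on the series. Within the data shown here, in a physicochemical assay for solubility, in phosphate buffer, measured as kinetic solubility (a lower number here means a less soluble compound, a higher number a more soluble compound), compound 1 (`CCc1nn2c(-c3c(OC)cc(C)cc3OC)cccc2c1N(CC1CCOCC1)CC1CC1`) gives 1600 nM and holds the lower of the two numbers so far. Compound 2 (`COCc1cc(OC)c(-c2cccc3c(N(CC4CCOCC4)CC4CC4)c(OC)nn23)c(OC)c1`) gives 5500 nM and lies higher by more than the scatter, but it differs from compound 1 in more than one place, so that gap cannot be tied to any single change. Compound 3 (`CCOCc1cc(OC)c(-c2cccc3c(N(CC4CCOCC4)CC4CC4)c(CC)nn23)c(OC)c1`) departs from compound 1 in one place: ethoxy in place of hydrogen on a saturated chain carbon bound to an aromatic carbon, read as ethoxy in place of hydrogen on a saturated chain carbon bound to an aromatic carbon. Among the measured compounds shown here, no measured pair isolates this change, so the expectation is loose: a modest rise, near the edge of the scatter. The expected size is a 1.8-fold higher number from compound 1 to compound 3 (0.24 log units; within the scatter) as an estimate. For compound 3 the estimated value is 2800 nM with an expected range of 1100 nM to 7000 nM around it.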

Compound 3, solubility: 1400 nM
Compound 3: middle estimate off by 2.0-fold (0.30 log units), on the high side; the measured number falls inside the stated range.
By their numbers in this assay, from the lowest: compounds 3 and 1 (each within the scatter of the next); then compound 2.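

In this assay, among these compounds, the one pair that isolates this position reads a 1.1-fold lower number from compound 1 to compound 3 (0.06 log units; within the scatter). Methyl to ethoxymethyl, which places ethoxy on a saturated chain carbon bound to an aromatic carbon, therefore gives no readable step on this core, and this single pair shows that the position can carry the ethoxy group with the number staying inside the scatter. No measurement on hand bears on why the two numbers stay together.

Open, going by these compounds, is whether an amine or a carboxylic acid at this same carbon, or a longer chain than ethoxymethyl, would give a step beyond the scatter. Among the compounds shown here, also open is whether the same change would read the same way with the other parts of compound 1 altered, since only one pair speaks to it.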